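Benzyl versus ynone-methyl on the distal piperidine carbon

The source may hold more compounds than are shown below. What is called first, only, known or untested is meant among the compounds shown, and "the series" means these compounds.

Working notes on three measured sulfonyl-bipiperidines and one open case. Compound 1 `Cc1cc(C)c(S(=O)(=O)N2CCC(N3CCC(c4ccccc4)CC3)CC2)c(C)c1` carries phenyl directly on the saturated ring carbon; in a functional assay on DLD-1 cells (Homo sapiens) for antiproliferative activity, read by CellTiter-Glo, with a stated time of 72 h (a lower number here means a stronger inhibitor, a higher number a weaker inhibitor), compound 1 gives 865 nM. Compound 2 `Cc1cc(C)c(S(=O)(=O)N2CCC(N3CCC(CCO)CC3)CC2)c(C)c1`, with the hydroxyethyl chain at that carbon, gives 19 nM. Compound 3 `C#CCCC(=O)CC1CCN(C2CCN(S(=O)(=O)c3c(C)cc(C)cc3C)CC2)CC1` gives 3 nM, the lowest number of the three: the step of a 290-fold lower number from compound 1 to compound 3 (2.46 log units; beyond the scatter) and the step of a 6.3-fold lower number from compound 2 to compound 3 (0.80 log units; beyond the scatter) both lie beyond the scatter, while the step of a 46-fold lower number from compound 1 to compound 2 (1.66 log units; beyond the scatter) shows how much of that gain already comes from losing the phenyl.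

Compound 4 `Cc1cc(C)c(S(=O)(=O)N2CCC(N3CCC(Cc4ccccc4)CC3)CC2)c(C)c1` is unmeasured. The change from compound 3 is phenyl in place of (but-3-yn-1-yl)carbonyl on a saturated chain carbon bound to a saturated ring carbon. Among the compounds with values here, two measured steps bear on it. The phenyl-to-ynone-methyl step from compound 1 to compound 3 ran strongly downward, and the hydroxymethyl-to-ynone-carbonyl step from compound 2 to compound 3 ran modestly downward; compound 4 undoes the carbonyl and reintroduces phenyl, so a clearly higher number is expected in this assay, though benzyl is not the phenyl of compound 1 and the reversal is taken as partial. The step from compound 3 to compound 4 is expected to be a 100-fold higher number from compound 3 to compound 4 (2.00 log units; beyond the scatter). Compound 4 is estimated at 300 nM, within 60 nM to 1500 nM.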

Compound 4, half-maximal inhibitory concentration: 3.5 nM
The estimate for compound 4 lay 86-fold (1.93 log units) above the measured number; measured number below the stated range.
By their numbers in this assay, from the lowest: compounds 3 and 4 (each within the scatter of the next); then compound 2; then compound 1.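

In this assay, the (but-3-yn-1-yl)carbonyl group proves dispensable at this place: a 1.2-fold higher number from compound 3 to compound 4 (0.07 log units; within the scatter) leaves compound 3 and compound 4 indistinguishable, so a carbonyl and an alkyne are not needed for a low number here. The high number of compound 1 does not extend to phenyl at the chain carbon, as a 250-fold lower number from compound 1 to compound 4 (2.39 log units; beyond the scatter) recovers nearly the whole gap through benzyl in place of phenyl on a saturated ring carbon, and a 5.4-fold lower number from compound 2 to compound 4 (0.73 log units; beyond the scatter) puts compound 4 beyond the scatter of the hydroxyethyl compound. Nothing available accounts for these steps.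

Still open, as far as these compounds go, is whether a longer chain carrying the phenyl keeps the number of compound 4. Also open, from the compounds shown here alone, is how an amine or a carboxylic acid in place of that phenyl would read.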